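Swapping the Benzyl Ring Substituent in a Nucleoside Series

The source may hold more compounds than are shown below. What is called first, only, known or untested is meant among the compounds shown, and "the series" means these compounds.

Compound 1, `OC[C@H]1O[C@@H](n2cnc3c(NCc4ccc(F)cc4)ncnc32)[C@H](O)[C@@H]1O`: 44300 nM
Compound 2, `OC[C@H]1O[C@@H](n2cnc3c(NCc4ccccc4Br)ncnc32)[C@H](O)[C@@H]1O`: > 166000 nM

In an ADME assay on NIH3T3 cells (Mus musculus) for cytotoxicity, with a stated time of 72 h (a higher number here means a weaker inhibitor, a lower number a stronger inhibitor), compound 1 gives 44300 nM. For compound 2 the result is only a limit, > 166000 nM, so its true value is not known. That value sits at the limit of > 166000 nM in this assay, at which 1 of the 2 values shown sits. Among the compounds with values here, the single measured step is an at least 3.7-fold higher number from compound 1 to compound 2 (0.57 log units; beyond the scatter), so compound 2 stands at the weak end of what has been measured.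

Compound 3, `Cc1ccc(CNc2ncnc3c2ncn3[C@@H]2O[C@H](CO)[C@@H](O)[C@H]2O)cc1`, is not yet measured. It differs from compound 2 by 4-methylphenyl in place of 2-bromophenyl on a saturated chain carbon bound to a nitrogen on an aromatic ring. Within the data shown here, the only step that bears on it is the one just described, which ran to a weaker inhibitor when 2-bromophenyl replaced 4-fluorophenyl; removing 2-bromophenyl again would be expected to reverse at least part of it. Compound 3 is therefore expected to give 80000 nM, within 30000 nM to 250000 nM. The expected step is an at least 2.0-fold lower number from compound 2 to compound 3 (0.31 log units; beyond the scatter), toward a stronger inhibitor, because compound 1 with 4-fluorophenyl gives 44300 nM.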

Compound 3, half-maximal inhibitory concentration: > 166000 nM
Compound 3 was reported as a limit; the forecaster's own chance of this, stated with the estimate: 45%; middle value at least 2.0-fold (0.31 log units) from the limit.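

Methyl in place of fluoro on an aromatic carbon is a change in one place, and in this assay it gives an at least 3.7-fold higher number from compound 1 to compound 3 (0.57 log units; beyond the scatter). A shift toward a weaker inhibitor therefore does not depend on 2-bromophenyl, since 4-methylphenyl goes the same way, and compound 1 remains the only one of the three with a measured number. The step between compound 2 and compound 3 cannot be read, because both are reported only as a limit: the limit of > 166000 nM in this assay, at which 2 of the 3 values shown sit.

From the compounds shown here alone, how far compound 2 and compound 3 really lie past that limit stays open. Also open, going by these compounds, is whether 4-chlorophenyl or 4-methoxyphenyl, on a saturated chain carbon bound to a nitrogen on an aromatic ring, would give a measured number like that of compound 1 or another limit.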